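From chloro to bromo on the shared core

The source may hold more compounds than are shown below. What is called first, only, known or untested is meant among the compounds shown, and "the series" means these compounds.

Values in a functional assay on MT4 cells (Homo sapiens) for cytotoxicity; on this read-out lower numbers stand for stronger inhibition and higher numbers for weaker inhibition:
- compound 1 `COc1ccc(S(=O)(=O)c2cccc(N)c2C#N)cc1`: > 200000 nM, a limit
- compound 2 `Cc1ccc(S(=O)(=O)c2cccc(N)c2C#N)cc1`: > 200000 nM, a limit
- compound 3 `N#Cc1c(N)cccc1S(=O)(=O)c1ccc(Cl)cc1`: > 5000 nM, a limit

Compound 3 stands at > 5000 nM, which is a limit and not a number. The other two compounds also stand at limits, so none of the three has a numerical value. Compound 4 `N#Cc1c(N)cccc1S(=O)(=O)c1ccc(Br)cc1` differs from compound 3 by a single change, (bromo in place of chloro on an aromatic carbon).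

Among the compounds with values here, two measured steps touch the same place on the ring: a step that the two limits leave unreadable from compound 1 to compound 3, and a step that the two limits leave unreadable from compound 2 to compound 3. Neither gives a size, so they offer no direction for the new change. No step beyond the scatter is therefore expected in this assay, and compound 4 may well be reported as a limit too. The expected step is a step that the limit leaves unreadable from compound 3 to compound 4. For compound 4 the estimate is 40000 nM, with an expected range from 5000 nM to 200000 nM.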

Compound 4, half-maximal inhibitory concentration: > 200000 nM
Compound 4 ended at the assay's limit; the forecaster's own chance of this, stated with the estimate: 85%; middle value at least 5.0-fold (0.69 log units) from the limit.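

In this assay compound 4 gives > 200000 nM as a limit and not a number. Compound 1, compound 2 and compound 3 also stand at limits, so none of their steps to compound 4 can be read. The compounds shown leave open whether methoxy, methyl, chloro and bromo differ at all on this read-out.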